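Swapping the Amine Tail: What to Expect for Compound 4

The source may report more compounds than this note shows. Statements on the series, on what has been measured and on what is new or still open speak of the compounds shown alone.

Of the compounds shown here, three have been measured in a functional assay (aorta) with Rattus norvegicus as the target; a higher number here means a weaker inhibitor, a lower number a stronger inhibitor. Compound 1 `CCN(CC)CCCOc1ccc(S(=O)(=O)c2c(C)cn3ccccc23)cc1` gives 3390 nM. Compound 2 `CCCN(CCC)CCCOc1ccc(S(=O)(=O)c2c(C)cn3ccccc23)cc1` gives 957 nM. Compound 3 `CCN(CC)CCCOc1ccc(S(=O)(=O)c2c(C(C)C)cn3ccccc23)cc1` gives 228 nM, the lowest of the three numbers.

Compound 2 differs from compound 1 in one place: dipropylamino in place of diethylamino on a saturated chain carbon, three bonds along the chain from an oxygen on an aromatic ring. This gave a 3.5-fold lower number from compound 1 to compound 2 (0.55 log units; beyond the scatter). Compound 3 differs from compound 1 elsewhere: isopropyl in place of methyl on an aromatic carbon. This gave a 15-fold lower number from compound 1 to compound 3 (1.17 log units; beyond the scatter).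

Compound 4 `CCCN(CCC)CCCOc1ccc(S(=O)(=O)c2c(C(C)C)cn3ccccc23)cc1` has not yet been measured. It differs from compound 3 by dipropylamino in place of diethylamino on a saturated chain carbon, three bonds along the chain from an oxygen on an aromatic ring, the same change that separates compound 1 from compound 2, at the same place. If the two changes act independently, compound 4 should combine the gain seen in compound 3 with the gain seen from compound 1 to compound 2. On that basis the step from compound 3 to compound 4 in this assay is expected to be a 3.0-fold lower number from compound 3 to compound 4 (0.48 log units; beyond the scatter), close to the earlier step, resting on compound 2 and its 957 nM. Compound 4 is therefore estimated at 75 nM, within 30 nM to 220 nM.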

Compound 4, half-maximal inhibitory concentration: 102 nM
Compound 4: middle estimate off by 1.4-fold (0.13 log units), on the low side; the measured number falls inside the stated range.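

In this assay, putting dipropylamino in place of diethylamino on the isopropyl core again gives a lower number, a 2.2-fold lower number from compound 3 to compound 4 (0.35 log units; beyond the scatter), so the change carries over from the methyl core with a similar size: the same change on two cores in this assay, a 3.5-fold lower number (0.55 log units; beyond the scatter) from compound 1 to compound 2 and a 2.2-fold lower number (0.35 log units; beyond the scatter) from compound 3 to compound 4, 1.6-fold (0.20 log units) apart, within the scatter of two such steps

Isopropyl in place of methyl on the aromatic carbon also holds up when the amine tail is dipropylamino, giving a 9.4-fold lower number from compound 2 to compound 4 (0.97 log units; beyond the scatter), and this step matches the one seen with diethylamino: the same change on two cores in this assay, a 15-fold lower number (1.17 log units; beyond the scatter) from compound 1 to compound 3 and a 9.4-fold lower number (0.97 log units; beyond the scatter) from compound 2 to compound 4, 1.6-fold (0.20 log units) apart, within the scatter of two such steps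

Across these four compounds the two changes therefore behave as if independent, but this rests on one pair of steps for each change in a single assay, and it shows neither why either change lowers the number nor that the same would hold on a different core.

The compounds shown leave open whether a longer amine such as dibutylamino or a ring amine such as piperidine would lower the number further. They also leave open what a tert-butyl or cyclopropyl group would do in place of isopropyl, and what a shorter tail such as 2-(dipropylamino)ethyl would do.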